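Pyridin-3-yl in Place of 2-Fluorophenyl: Expected Cytotoxicity

This account rests on a few compounds, and the source may have more. Where it says the series, first, only, none or still open, it means among the compounds named here.

Compound 1, `CC1=C(/C=C/C(=O)/C=C/c2ccc(Br)cc2)C(C)(C)CCC1`, gives 34500 nM in a functional assay on Hep cells (Homo sapiens) for cytotoxicity, read by sulforhodamine B assay, with a stated time of 48 h; on this read-out higher numbers stand for weaker inhibition and lower numbers for stronger inhibition.
Compound 2, `CC1=C(/C=C/C(=O)/C=C/c2ccc(F)cc2)C(C)(C)CCC1`, gives 55800 nM in this assay.
Compound 3, `CC1=C(/C=C/C(=O)/C=C/c2ccccc2F)C(C)(C)CCC1`, gives 23600 nM in this assay.

Compound 3 holds the lowest of the three numbers in this assay. The step of a 1.5-fold lower number from compound 1 to compound 3 (0.16 log units; within the scatter) stays within the scatter, while a 2.4-fold lower number from compound 2 to compound 3 (0.37 log units; beyond the scatter) reaches modestly beyond it; a 1.6-fold higher number from compound 1 to compound 2 (0.21 log units; within the scatter) is likewise small.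

Compound 4, `CC1=C(/C=C/C(=O)/C=C/c2cccnc2)C(C)(C)CCC1`, differs from compound 3 in one place: pyridin-3-yl in place of 2-fluorophenyl on a double-bonded chain carbon bound to a double-bonded chain carbon. Within the data shown here, none of the measured steps exchanges a carbon-only ring for a ring with a hetero atom; the three measured steps change only the halogen and where it sits, and each of them is small. Among the measured compounds shown here, there is thus no direct precedent, and the nearest evidence points to small movements in this assay. Compound 4 is therefore expected to show a step of a 1.3-fold higher number from compound 3 to compound 4 (0.10 log units; within the scatter), not clearly beyond the scatter. Compound 4 is estimated at 30000 nM, with a range from 12000 nM to 75000 nM.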

Compound 4, half-maximal inhibitory concentration: 45600 nM
For compound 4 the middle estimate is 1.5-fold (0.18 log units) below the measured one; low and high end bracket the measured number.
By their numbers in this assay, from the lowest: compounds 3, 1, 4 and 2 (each within the scatter of the next, the first and the last beyond it).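

Among these compounds, the first exchange of a carbon-only ring for a ring with a hetero atom, which also brings in a hydrogen-bond acceptor, leaves the number in this assay within the scatter of the 2-fluorophenyl compound (a 1.9-fold higher number from compound 3 to compound 4 (0.29 log units; within the scatter)). The same holds against the two compounds with a substituent in the 4-position of the phenyl ring (a 1.2-fold lower number from compound 2 to compound 4 (0.09 log units; within the scatter); a 1.3-fold higher number from compound 1 to compound 4 (0.12 log units; within the scatter)), so pyridin-3-yl on this double-bonded chain carbon lies within the scatter of compound 2 and compound 3, although those two lie beyond the scatter of each other. Nothing available explains why these steps stay so small.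

From the compounds shown here alone, whether pyridin-2-yl or pyridin-4-yl would behave like pyridin-3-yl at this place remains open. So does whether a phenyl ring bearing an amine or a carboxylic acid would move the number beyond the scatter in this assay.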